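A few compounds are considered here, and "the series" means these few. Any claim that something is new, unique, unknown or untested is made for them only; others in the source may bear on it.

Measured so far:
compound 1 `COC(=O)Cn1nc2c(n1)C(=O)C(C)=C(C)C2=O` — 4 ug/mL
compound 2 `COC(=O)C(C)n1n[n+]([O-])c2cc(C)c(C)cc21` — > 100 ug/mL

Among the measured compounds shown here, in a functional assay on KB cells (Homo sapiens) for inhibition, read by colorimetric assay, with a stated time of 72 h (a lower number here means that less compound is needed, a higher number that more compound is needed for the effect), compound 1 gives 4 ug/mL, the only number in hand. Compound 2 stops at > 100 ug/mL, which is a limit of this assay and not a number (the limit of > 100 ug/mL in this assay, at which 1 of the 2 values shown sits). Compound 3 `CC1=C(C)C(=O)c2nn(Cc3ccccc3)nc2C1=O` awaits measurement in this assay; it differs from compound 1 by phenyl in place of methoxycarbonyl on a saturated chain carbon bound to an aromatic nitrogen. For the measured compounds named here, no step between measured compounds calibrates this change, so the step from compound 1 to compound 3 is expected to be small, a 1.3-fold lower number from compound 1 to compound 3 (0.12 log units; within the scatter), within the scatter or slightly toward less compound needed. Compound 3 is estimated at 3 ug/mL, between 0.8 ug/mL and 15 ug/mL.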

Compound 3, concentration for half-maximal effect: 3.5 ug/mL
Compound 3: the middle estimate sits 1.2-fold (0.07 log units) below what was measured, and the stated range covers the measured number.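

Phenyl in place of methoxycarbonyl on a saturated chain carbon bound to an aromatic nitrogen gives a 1.1-fold lower number from compound 1 to compound 3 (0.06 log units; within the scatter) in this assay. For this pair, the value therefore does not depend on keeping the methoxycarbonyl group, and a six-membered aromatic ring of carbon only serves equally well at this place. Nothing measured here bears on why the two groups read alike. As far as these compounds go, whether an amine, a carboxylic acid or a longer chain at this place would hold the value remains open. A phenyl ring carrying a methoxy or chloro substituent is equally untested by the compounds shown.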